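The source may hold more compounds than are shown below. What is called first, only, known or untested is meant among the compounds shown, and "the series" means these compounds.

Notes on the series. In a functional assay on SK-OV-3 cells (Homo sapiens) for cytotoxicity, read by sulforhodamine B assay (a higher number here means a weaker inhibitor, a lower number a stronger inhibitor), compound 1 `O=C(/C=C\c1ccc(O)cc1)O[C@@H]1[C@H](O[C@@H]2CCCC[C@@H]2O)O[C@H](CO)[C@@H](O)[C@H]1O` gives only a limit of the assay, > 10000 nM. In this assay compound 2 `O=C(/C=C\c1ccc(O)cc1)O[C@H]1[C@H](O[C@H]2CCCC[C@H]2O)O[C@H](CO)[C@@H](O)[C@@H]1O` likewise gives only a limit, > 10000 nM. For the measured compounds named here, the step that the two limits leave unreadable from compound 1 to compound 2 is therefore not readable, because of the limit of > 10000 nM in this assay, at which 2 of the 2 values shown sit; the pair shows only that the fact that compounds 1 and 2 differ only in the configuration as drawn did not bring either compound inside the measured range. Compound 2 thus stands at the limit, with no number of its own. Compound 3 `O=C(/C=C/c1ccc(O)cc1)O[C@H]1[C@H](O[C@@H]2CCCC[C@@H]2O)O[C@H](CO)[C@@H](O)[C@@H]1O` differs from compound 2 as follows: the two compounds have the same atoms and bonds and differ only in configuration as drawn: 3 of 8 stereo elements differ; a stereocentre at a saturated ring carbon is drawn S in compound 2 and R in compound 3; a stereocentre at a saturated ring carbon is drawn R in compound 2 and S in compound 3; a double bond is drawn Z in compound 2 and E in compound 3. Going by the values given here, no measured step bears directly on this change, and the one step available, a step that the two limits leave unreadable from compound 1 to compound 2, gives no size. Two configurational variants of the same atoms and bonds both sit at the limit, so a readable value for a third is not expected. The step that the limit leaves unreadable from compound 2 to compound 3 is expected to be none beyond the scatter. Compound 3 is estimated at 15000 nM in this assay, range 5000 nM to 50000 nM, most likely reported again as a limit.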

Compound 3, half-maximal inhibitory concentration: > 10000 nM
Compound 3 gave a limit, no number; the forecaster's own chance of this, stated with the estimate: 80%; the middle value lies beyond the limit too.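

In this assay compound 3 gives only a limit of the assay, > 10000 nM and no number of its own. The steps from compound 1 and from compound 2 to compound 3 cannot be read. On these data alone, it remains open whether these three configurations differ in this assay at all.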